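A few compounds are considered here, and "the series" means these few. Any claim that something is new, unique, unknown or untested is made for them only; others in the source may bear on it.

Measured so far in an assay on isolated protein for agonist activity at Bile acid receptor (Homo sapiens), read by TR-FRET; a lower number here means that less compound is needed, a higher number that more compound is needed for the effect:
- compound 1 `CCn1c(-c2ccc(OCc3c(-c4c(Cl)cccc4Cl)noc3C(C)C)cc2)nc2ccc(C(=O)O)cc21` gives 19.3 nM
- compound 2 `CC(C)c1onc(-c2c(Cl)cccc2Cl)c1COc1ccc(-c2nc3ccc(C(=O)O)cc3n2C(C)C)cc1` gives 56.7 nM
- compound 3 `CC(C)c1onc(-c2c(Cl)cccc2Cl)c1COc1ccc(-c2nc3ccc(C(=O)O)cc3n2CC2CC2)cc1` gives 29.1 nM

Compound 3 stands second highest of the three numbers, yet its gaps to both neighbours lie within the scatter: a 1.5-fold higher number from compound 1 to compound 3 (0.18 log units; within the scatter) and a 1.9-fold lower number from compound 2 to compound 3 (0.29 log units; within the scatter). Compound 4 `CC(C)c1onc(-c2c(Cl)cccc2Cl)c1COc1ccc(-c2nc3ccc(C(=O)O)cc3n2C2CC2)cc1` keeps the shared core and alters only the group on the aromatic nitrogen: cyclopropyl in place of cyclopropylmethyl on an aromatic nitrogen. The steps bearing on this place, a 1.5-fold higher number from compound 1 to compound 3 (0.18 log units; within the scatter) and a 1.9-fold lower number from compound 2 to compound 3 (0.29 log units; within the scatter), were small, while a 2.9-fold higher number from compound 1 to compound 2 (0.47 log units; beyond the scatter) was the only one beyond the scatter. A change of this size at the same place is therefore expected to move this assay little, if at all, with the step estimated as a 1.4-fold higher number from compound 3 to compound 4 (0.14 log units; within the scatter). For compound 4 the expected value is 40 nM, within a range from 15 nM to 110 nM.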

Compound 4, half-maximal effective concentration: 117 nM
The estimate for compound 4 lay 2.9-fold (0.47 log units) below the measured number, outside the stated range (above it).
By their numbers in this assay, from the lowest: compounds 1, 3 and 2 (each within the scatter of the next, the first and the last beyond it); then compound 4.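

On the aromatic nitrogen, cyclopropyl is the first group to stand apart in this assay from all the others shown, with a 4.0-fold higher number from compound 3 to compound 4 (0.60 log units; beyond the scatter) and a 2.1-fold higher number from compound 2 to compound 4 (0.31 log units; beyond the scatter) and also a 6.1-fold higher number from compound 1 to compound 4 (0.78 log units; beyond the scatter). The three-membered ring alone therefore does not preserve the number, since cyclopropyl and cyclopropylmethyl both carry it yet differ beyond the scatter. No measurement shown explains this difference. Open, from the compounds shown here alone, is how a longer chain such as propyl or a larger ring such as cyclobutyl on this nitrogen would read.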